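Aryl swap on the shared core: compound 3 to compound 4

The source may report more compounds than this note shows. Statements on the series, on what has been measured and on what is new or still open speak of the compounds shown alone.

Measured so far in a functional assay on BMDM cells (Mus musculus, strain C57BL/6) for inhibition, with a stated time of 2 days; on this read-out higher numbers stand for weaker inhibition and lower numbers for stronger inhibition:
compound 1 `Nc1cccc(-c2cn(CC(=O)Nc3nccs3)nn2)c1` gives 1270 nM
compound 2 `O=C(Cn1cc(-c2ccncc2)nn1)Nc1nccs1` gives 2 nM
compound 3 `O=C(Cn1cc(-c2cccc(Cl)c2)nn1)Nc1nccs1` gives only a limit of the assay, > 30000 nM

Compound 3 thus sits at the limit of > 30000 nM in this assay, at which 1 of the 3 values shown sits, the weak end of the three. The steps that reach it are both large and both toward weaker inhibition: an at least 23-fold higher number from compound 1 to compound 3 (1.37 log units; beyond the scatter) and an at least 15000-fold higher number from compound 2 to compound 3 (4.17 log units; beyond the scatter). Compound 4 `O=C(Cn1cc(-c2ccc(F)cc2)nn1)Nc1nccs1` differs from compound 3 by 4-fluorophenyl in place of 3-chlorophenyl on an aromatic carbon. Among the compounds with values here, no measured pair tests a halogen placed elsewhere on the phenyl ring, so the step from compound 3 to compound 4 in this assay is expected to be small or none beyond the scatter, leaving compound 4 weak. Compound 4 is estimated at 25000 nM, range 3000 nM to 100000 nM, an expected step of an at least 1.2-fold lower number from compound 3 to compound 4 (0.07 log units; that floor lies within the scatter).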

Compound 4, half-maximal inhibitory concentration: 190 nM
Compound 4: middle estimate off by 130-fold (2.12 log units), on the high side; measured number outside the range, below it.
By their numbers in this assay, from the lowest: compound 2; then compound 4; then compound 1. At a limit, above all of these: compound 3.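

A phenyl ring at this position of the shared core can still inhibit well, since 4-fluorophenyl in place of 3-chlorophenyl gives an at least 150-fold lower number from compound 3 to compound 4 (2.19 log units; beyond the scatter). This group still falls short of pyridin-4-yl, with a 95-fold higher number from compound 2 to compound 4 (1.98 log units; beyond the scatter), yet it improves on 3-aminophenyl, with a 6.7-fold lower number from compound 1 to compound 4 (0.83 log units; beyond the scatter). Compound 3 stands at a limit, so its step is only a floor: the limit of > 30000 nM in this assay, at which 1 of the 4 values shown sits.

The change alters both the halogen and its place on the phenyl ring, and the compounds shown do not separate the two. Also open, as far as these compounds go, is how a methoxy or a carboxylic acid on that phenyl ring would read.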